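The source may report more compounds than this note shows. Statements on the series, on what has been measured and on what is new or still open speak of the compounds shown alone.

Working notes on the series, in a functional assay on THP-1 cells (Homo sapiens) for cytotoxicity, read by MTT assay, with a stated time of 24 h; a higher number here means a weaker inhibitor, a lower number a stronger inhibitor. Compound 1 (`COc1cc(/C=C2\CN(C)C/C(=C\c3ccc(Cl)cc3)C2=O)cc(OC)c1`) gives 5860 nM and compound 2 (`COc1cc(/C=C2\CN(C)C/C(=C\c3ccc(Cl)cc3Cl)C2=O)cc(OC)c1`) gives 6070 nM. Among the compounds with values here, compound 2 therefore stands level with compound 1, the only other number available, and the two cannot be separated within the scatter.

The next structure is compound 3 (`COc1cc(/C=C2\CN(C)C/C(=C\c3cccc([N+](=O)[O-])c3)C2=O)cc(OC)c1`). The change is 3-nitrophenyl in place of 2,4-dichlorophenyl on a double-bonded chain carbon bound to a double-bonded ring carbon. In words, this is 3-nitrophenyl in place of 2,4-dichlorophenyl on a double-bonded chain carbon bound to a double-bonded ring carbon.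

Within the data shown here, only one measured step bears on this: a 1.0-fold higher number from compound 1 to compound 2 (0.02 log units; within the scatter), with chloro in place of hydrogen on an aromatic carbon. Among the measured compounds shown here, that step stays within the scatter, but it is a small guide, since no measured compound carries 3-nitrophenyl and the data offer no direct precedent. No step beyond the scatter is therefore expected in this assay, and no direction can be firmly assigned.

The expected change is a 1.3-fold lower number from compound 2 to compound 3 (0.10 log units; within the scatter). For compound 3 the estimated value is 4800 nM, with an expected range of 1900 nM to 12000 nM.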

Compound 3, half-maximal inhibitory concentration: 1770 nM
Estimate against measurement, compound 3: 2.7-fold (0.43 log units) above; the whole stated range lies above it.
By their numbers in this assay, from the lowest: compound 3; then compounds 1 and 2 (each within the scatter of the next).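

In this assay the group on a double-bonded chain carbon bound to a double-bonded ring carbon now proves able to shift the number: 3-nitrophenyl in place of 2,4-dichlorophenyl gives a 3.4-fold lower number from compound 2 to compound 3 (0.54 log units; beyond the scatter) and 3-nitrophenyl in place of 4-chlorophenyl gives a 3.3-fold lower number from compound 1 to compound 3 (0.52 log units; beyond the scatter) as the matching step. Within the data shown here, both steps are modest but beyond the scatter, whereas the added chloro separating the two chlorinated compounds moved nothing beyond it, so compound 3 is the first compound that stands apart. No measurement at hand explains this separation.

On these data alone, what remains open is whether the step belongs to the nitro group itself or would also appear with another group on the phenyl ring, such as an amine or a carboxylic acid. The compounds shown also leave open whether the step would persist with changes elsewhere, since all three share the rest of the core of compound 1 and differ only in this one group.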